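The source may report more compounds than this note shows. Statements on the series, on what has been measured and on what is new or still open speak of the compounds shown alone.

Working notes on the series. Two analogues on the shared core have been run through a physicochemical assay for lipophilicity, using the shake flask method, measured as octanol-water partition, at pH 7.4; a lower number here means a more polar compound, a higher number a more lipophilic compound. Compound 1, `C[C@@H](Nc1c(C(N)=O)cnc2ccc(C#N)cc12)c1ccc(Cl)cc1`, gives 3.5 in this assay. Compound 2, `NC(=O)c1cnc2ccc(-c3cccnc3)cc2c1SC1CCCC1`, gives 3.2 in this assay; the two numbers sit within the scatter of each other, so no order can be read between them. Compound 3, `C[C@H](Nc1c(C(N)=O)cnc2ccc(-c3cccnc3)cc12)C1CCOCC1`, is not yet measured. Relative to compound 2 the change is (1-(oxan-4-yl)ethyl)amino in place of cyclopentylsulfanyl on an aromatic carbon: one hydrogen-bond donor and a second acceptor enter where none and one stood. A step beyond the scatter, downward, is expected: a number 1.10 log units lower from compound 2 to compound 3 (beyond the scatter). For compound 3 the estimate in this assay is 2.1, between 1.5 and 2.7.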

Compound 3, distribution coefficient: 2.5
The estimate for compound 3 lay 0.40 log units below the measured number; measured number inside the range.
By their numbers in this assay, from the lowest: compound 3; then compounds 2 and 1 (each within the scatter of the next).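

Among the compounds shown here, at this position, on an aromatic carbon opposite the ring nitrogen, (1-(oxan-4-yl)ethyl)amino in place of cyclopentylsulfanyl gives a number 0.70 log units lower from compound 2 to compound 3 (beyond the scatter) in this assay, the first step that can be read. It shows that this one place can move the number beyond the scatter. Nothing at hand bears on the origin of this step.

The change replaces the sulfur link and the ring together, and the compounds shown leave open how much of the step belongs to each. Cyclopentylamino or oxan-4-ylsulfanyl at this position would separate the two.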